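Dopamine transporter inhibition: urea series, trifluoromethyl removal

The source may report more compounds than this note shows. Statements on the series, on what has been measured and on what is new or still open speak of the compounds shown alone.

Measured compounds:
compound 1 `O=C(NCCCCC(c1ccc(F)cc1)c1ccc(F)cc1)Nc1ccc(Cl)cc1`: 82%
compound 2 `O=C(NCCCCC(c1ccc(F)cc1)c1ccc(F)cc1)Nc1ccc(Cl)c(C(F)(F)F)c1`: 90%
compound 3 `Cc1ccc(C(CCCCNC(=O)Nc2ccc(Cl)c(C(F)(F)F)c2)c2ccc(C)cc2)cc1`: 38%

All three were tested in an ADME assay on isolated protein for inhibition of sodium-dependent dopamine transporter (Homo sapiens), tested at 10 uM; a lower number here means less inhibition, a higher number more inhibition at the concentration tested (going by the name of the read-out). Compound 2 and compound 1 differ in one place, (hydrogen in place of trifluoromethyl on an aromatic carbon), and the step of a number 8 percentage points lower from compound 2 to compound 1 (within the scatter). Compound 3 carries the same urea end as compound 2 but a different core; the difference between the two cores is not broken down here. In this assay compound 3 stands lowest of the three, with compound 1 the nearest and compound 2 the furthest, both beyond the scatter.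

Compound 4, `Cc1ccc(C(CCCCNC(=O)Nc2ccc(Cl)cc2)c2ccc(C)cc2)cc1`, has not yet been measured in this assay. Going by the values given here, it differs from compound 3 by hydrogen in place of trifluoromethyl on an aromatic carbon, the same change as the one from compound 2 to compound 1, at a place described in the same words. Among the compounds with values here, only one measured instance of this change exists, so the expectation rests on compound 2 and compound 1, whose step a number 8 percentage points lower from compound 2 to compound 1 (within the scatter) was within the scatter. The step expected for compound 4 is a number 6 percentage points lower from compound 3 to compound 4 (within the scatter). The estimate for compound 4 in this assay is 32%, with an expected range from 15% to 50%. Whether the change behaves the same on the core of compound 3 as on the core of compound 1 is not known from these data, hence the wide range.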

Compound 4, a percentage reported as inhibition, at one concentration (the size of the read-out at that concentration, not a potency): 59%
For compound 4 the middle estimate is 27 percentage points below the measured one; the measured number lies above the stated range.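

In this assay, the change from 4-chloro-3-(trifluoromethyl)phenyl to 4-chlorophenyl on the core of compound 3 gives a clear shift in the read-out (a number 21 percentage points higher from compound 3 to compound 4 (beyond the scatter)). The same change therefore does not carry over unchanged from one core to the other in this series, and its size and direction on one core cannot be assumed on the other: the same change on two cores in this assay, a number 8 percentage points lower (within the scatter) from compound 2 to compound 1 and a number 21 percentage points higher (beyond the scatter) from compound 3 to compound 4, 29 percentage points apart, beyond the scatter of two such steps. This rests on a single pair per core at one test concentration, so it shows that the core matters for this change but not which part of the core is responsible, nor what the change would do on a third core.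

The compounds shown leave open whether a nitrile or a methoxy group in place of trifluoromethyl, on an aromatic carbon ortho to the chloro group, would also depend on the core, and whether a chloro group in place of the fluoro or methyl groups of the two cores would give a step closer to the one on the core of compound 1 or the one on the core of compound 3. They also leave open how the change behaves with a longer chain, or with an amide in place of the urea.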